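Changing the amide substituent of compound 2: what to expect

The source may report more compounds than this note shows. Statements on the series, on what has been measured and on what is new or still open speak of the compounds shown alone.

Of the compounds shown here, two have so far been tested in an assay on isolated protein for inhibition of calcium/calmodulin-dependent protein kinase type II subunit alpha (Homo sapiens), read by HTRF, tested at 10 uM; a higher number here means more inhibition at the concentration tested (going by the name of the read-out), a lower number less inhibition. Compound 1 `O=C(CN1CCN(c2ncnc3c2CN(Cc2ccccc2)CC3)CC1)Nc1cc(F)ccc1F` gives 0% in this assay. Compound 2 `CN(CCCn1ccnc1)C(=O)[C@@H]1CCCN1c1nccc(Nc2ccccc2)n1` gives 0% in this assay. Compound 2 thus stands level with compound 1 at the digits reported, and the two values lie within the usual scatter of each other, so neither compound shows measurable inhibition at the concentration tested.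

Compound 3 `CN(C)CC(C)(C)CNC(=O)[C@@H]1CCCN1c1nccc(Nc2ccccc2)n1` has not yet been measured. It differs from compound 2 at one place: (2-((dimethylamino)methyl)-2-methylpropyl)amino in place of (3-(1H-imidazol-1-yl)propyl)(methyl)amino on a carbonyl carbon. The group that leaves carries a five-membered aromatic ring; the group that enters has no ring and brings one hydrogen-bond donor in place of none.

Among the measured compounds shown here, no step between two measured compounds has been reported, so nothing here tells how a change on the carbonyl carbon moves the read-out. Both measured compounds sit at the floor of the assay, and a change at this one place is not expected to lift compound 3 beyond the scatter. The step is therefore expected to be a number 2 percentage points higher from compound 2 to compound 3 (within the scatter), none beyond the scatter. Compound 3 is expected to give about 2% in this assay, within a range from -8% to 15%.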

Compound 3, a percentage reported as inhibition, at one concentration (the size of the read-out at that concentration, not a potency): 0%
Compound 3: the middle estimate sits 2 percentage points above what was measured, and the stated range covers the measured number.
By their numbers in this assay, from the lowest: compounds 1, 2 and 3 (each within the scatter of the next).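

In this assay, among the compounds shown here, the one step readable at this position is no change at the digits printed from compound 2 to compound 3 (within the scatter), so placing (2-((dimethylamino)methyl)-2-methylpropyl)amino on the carbonyl carbon instead of (3-(1H-imidazol-1-yl)propyl)(methyl)amino gives no measurable inhibition at the concentration tested. This single exchange removes the five-membered aromatic ring and adds a hydrogen-bond donor, and neither difference, taken together with the other, produces a readable signal, although the two cannot be separated here. Nothing available explains this result.

With compound 2 and compound 3 both at the bottom of the read-out, a flat step does not prove that this position has no influence, since any loss of inhibition would be invisible and only a gain could be seen. Still open, as far as these compounds go, is whether a chain ending in a carboxylic acid, a morpholine ring or a simple methylamino group on that carbonyl carbon would lift the number beyond the scatter, or whether any inhibition requires a change elsewhere on the shared core.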